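Methyl Added to the Nitro-Bearing Ring of Compound 2

The source may hold more compounds than are shown below. What is called first, only, known or untested is meant among the compounds shown, and "the series" means these compounds.

For the measured compounds named here, compound 2 `O=[N+]([O-])c1cccc(Nc2nc3ncccc3n2Cc2ccccc2)c1` gives 24200 nM in a functional assay on MCF7 cells (Homo sapiens) for antiproliferative activity, read by MTT assay, with a stated time of 72 h (a higher number here means a weaker inhibitor of growth, a lower number a stronger inhibitor of growth), the lowest of the two numbers measured so far, while compound 1 `c1ccc(Cn2c(Nc3ccccc3)nc3ncccc32)cc1` gives 52500 nM. Going by the values given here, the change a 2.2-fold lower number from compound 1 to compound 2 (0.34 log units; beyond the scatter) is the only measured step. Compound 3 `Cc1ccc(Nc2nc3ncccc3n2Cc2ccccc2)cc1[N+](=O)[O-]` differs from compound 2 by methyl in place of hydrogen on an aromatic carbon. Among the compounds with values here, no measured step covers a methyl in place of hydrogen on an aromatic carbon, and the one recorded step, the nitro addition, was modest. Compound 3 is therefore expected to stay close to compound 2, with a 1.3-fold lower number from compound 2 to compound 3 (0.13 log units; within the scatter) a step not beyond the scatter. The estimate for compound 3 in this assay is 18000 nM, between 8000 nM and 45000 nM.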

Compound 3, concentration for 50% growth inhibition: 27800 nM
For compound 3 the middle estimate is 1.5-fold (0.19 log units) below the measured one; the range from low to high includes it.
By their numbers in this assay, from the lowest: compounds 2, 3 and 1 (each within the scatter of the next, the first and the last beyond it).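

Methyl on the aromatic carbon ortho to a nitro group and para to a large group gives a 1.1-fold higher number from compound 2 to compound 3 (0.06 log units; within the scatter) in this assay, so this position takes a single added carbon with no difference beyond the scatter. For the compounds shown here, the earlier compounds could not show this, as their only step concerned the nitro group and not this carbon. No evidence on hand accounts for this result. Still open, going by these compounds, is whether an amine, a carboxylic acid or a longer chain on this same carbon would give a step beyond the scatter.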